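The source may hold more compounds than are shown below. What is called first, only, known or untested is meant among the compounds shown, and "the series" means these compounds.

Measured compounds:
Compound 1, `Cc1cc(C)cc(SCc2ccc(C(=O)Nc3ccccc3N)cc2)c1`: 2490 nM
Compound 2, `Nc1ccccc1NC(=O)/C=C/c1ccc(CSCCc2ccccc2)cc1`: "not determined" (no result reported)

Among the compounds with values here, compound 1 is the only entry with a number in a functional assay on HCT-116 cells (Homo sapiens) for antiproliferative activity, read by CCK-8 assay, with a stated time of 72 h; on this read-out higher numbers stand for weaker inhibition and lower numbers for stronger inhibition; in this assay compound 1 gives 2490 nM. Compound 2, whose structure carries the phenethyl group on sulfur together with a different linker to the amide, was not assigned a value, so nothing can be drawn from it. Within the data shown here, compound 1 therefore stands alone, and no step between measured compounds is available to calibrate the effect of changing the group on sulfur.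

The compound to be measured is compound 3, `Nc1ccccc1NC(=O)c1ccc(CSCCc2ccccc2)cc1`. It keeps the core of compound 1 and differs only in this way: phenethyl in place of 3,5-dimethylphenyl on a sulfur. The two compounds contain the same atoms, joined differently.

Among the measured compounds shown here, with no measured step to rest on, the account expects the change from compound 1 to compound 3 to stay close to the usual scatter, with at most a small shift toward weaker inhibition; the estimated step is a 1.3-fold higher number from compound 1 to compound 3 (0.11 log units; within the scatter). Compound 3 is accordingly estimated at 3200 nM, within a range from 1000 nM to 10000 nM.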

Compound 3, half-maximal inhibitory concentration: 2810 nM
Estimate against measurement, compound 3: 1.1-fold (0.06 log units) above, within the range that was stated.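

In this assay, within the data shown here, the exchange of 3,5-dimethylphenyl for phenethyl on a sulfur gives a 1.1-fold higher number from compound 1 to compound 3 (0.05 log units; within the scatter) and so supplies the first measured step for a change at this position. Within this one pair, the same atoms joined differently leave compound 1 and compound 3 indistinguishable in this read-out, although one group has its aromatic ring carrying two methyl groups and the other has an unsubstituted ring on a chain; this finding extends no further than these two compounds. No measurement is available that would explain this result or tie it to any property of either group.

Both groups shown on the sulfur contain carbon only, so it remains open whether an amine, a carboxylic acid or a longer chain such as phenylbutyl at the same place would be distinguished from them in this assay. From the compounds shown here alone, it also remains open whether the different linker to the amide seen in compound 2 would shift the number when phenethyl sits on the sulfur.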